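Ethoxy for trifluoromethyl on the anilino ring

This account rests on a few compounds, and the source may have more. Where it says the series, first, only, none or still open, it means among the compounds named here.

Of the compounds shown here, two sharing one core have been measured in a functional assay on HGC-27 cells (Homo sapiens) for cytotoxicity, read by MTT assay, with a stated time of 72 h; on this read-out higher numbers stand for weaker inhibition and lower numbers for stronger inhibition. Compound 1, `FC(F)(F)c1ccc(CSc2nc(Nc3cccc(Br)c3)c3ccccc3n2)cc1`, gives 18300 nM in this assay. Compound 2, `FC(F)(F)c1ccc(CSc2nc(Nc3ccc(C(F)(F)F)cc3)c3ccccc3n2)cc1`, gives 7560 nM. Among the compounds with values here, the one step between them, a 2.4-fold lower number from compound 1 to compound 2 (0.38 log units; beyond the scatter), leaves compound 2 with the lowest of the two numbers so far, beyond the scatter from compound 1.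

Compound 3, `CCOc1ccc(Nc2nc(SCc3ccc(C(F)(F)F)cc3)nc3ccccc23)cc1`, carries the change (ethoxy in place of trifluoromethyl on an aromatic carbon), sitting para to a large group. Within the data shown here, no measured step bears directly on this exchange: the only step available, a 2.4-fold lower number from compound 1 to compound 2 (0.38 log units; beyond the scatter), moved both the substituent and its place on the ring at once, and it offers no guide to replacing trifluoromethyl by ethoxy at the same place. The expectation is therefore a step of no clear direction, most likely within the scatter, with a 1.2-fold higher number from compound 2 to compound 3 (0.08 log units; within the scatter) as the central guess. Compound 3 is estimated at 9000 nM in this assay, with a range from 3000 nM to 30000 nM.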

Compound 3, half-maximal inhibitory concentration: 33000 nM
Beside the measured number, compound 3's estimate is 3.7-fold (0.56 log units) below it; measured number above the stated range.
By their numbers in this assay, from the lowest: compound 2; then compounds 1 and 3 (each within the scatter of the next).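

Within the data shown here, on an aromatic carbon para to a large group, this is the first direct reading of one substituent exchanged for another at the same place: in this assay, ethoxy in place of trifluoromethyl gives a 4.4-fold higher number from compound 2 to compound 3 (0.64 log units; beyond the scatter) and so shows that the number at this place depends on which group is present. The other new comparison, a 1.8-fold higher number from compound 1 to compound 3 (0.26 log units; within the scatter), leaves 4-ethoxyphenyl and 3-bromophenyl on the nitrogen unseparated, so among these three compounds only compound 2, with 4-(trifluoromethyl)phenyl, stands apart from both others beyond the scatter. No experimental evidence shown here accounts for the difference between trifluoromethyl and ethoxy.

The compounds shown leave open whether the lower number of compound 2 belongs to trifluoromethyl in particular, since a single exchange cannot say how a methoxy group, a chlorine atom, a nitrile or an amine would read at the same place. They also leave open how much the place itself matters, since no pair shown holds one substituent fixed while moving it around the ring.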